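Swapping the aryl group on the amide of compound 1

The compounds below may be only part of what the source reports. "The series", "measured", "known", "first", "only" and "open" are said of these compounds alone.

Compound 1, `C=Cc1cccc(C(=O)NCN2CCC(c3cccc[n+]3[O-])CC2)c1`, is the starting point. In a functional assay on HEK293 cells for agonist activity at D(4) dopamine receptor (Homo sapiens), read by FLIPR (a higher number here means that more compound is needed for the effect, a lower number that less compound is needed), compound 1 gives 68 nM. Among the measured compounds shown here, the only other measured compound, compound 2, `O=C(CN1CCC(c2cccc[n+]2[O-])CC1)Nc1cccc(OC(F)(F)F)c1`, shares the piperidine-bearing core but carries its amide in the reversed sense; in this assay compound 2 gives 135 nM. The two numbers lie within the usual scatter of each other, so neither compound can be called the more active on this evidence.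

Compound 3, `Cc1cc(C(=O)NCN2CCC(c3cccc[n+]3[O-])CC2)ccc1Cl`, keeps the whole of compound 1 except the aryl group on the carbonyl carbon: 4-chloro-3-methylphenyl in place of 3-vinylphenyl on a carbonyl carbon. For the measured compounds named here, no measured pair shows what such a swap does here, so the expectation rests on compound 1 alone. The step from compound 1 to compound 3 is expected to be small, about a 1.2-fold higher number from compound 1 to compound 3 (0.07 log units; within the scatter), with no clear direction beyond the scatter. Compound 3 is therefore estimated at 80 nM, within a range from 25 nM to 250 nM.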

Compound 3, half-maximal effective concentration: 2460 nM
Compound 3: middle estimate off by 31-fold (1.49 log units), on the low side; measured number above the stated range.
By their numbers in this assay, from the lowest: compounds 1 and 2 (each within the scatter of the next); then compound 3.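

The aryl group on the carbonyl carbon turns out to matter in this assay: putting 4-chloro-3-methylphenyl in place of 3-vinylphenyl gives a 36-fold higher number from compound 1 to compound 3 (1.56 log units; beyond the scatter) and so calls for much more compound to reach the effect. Both groups have the same count of heavy atoms, and neither has any hydrogen-bond donors or acceptors, so these counts alone do not foretell the result at this position. Nothing measured here accounts for the size of this step.

Going by these compounds, the swap brings in a chlorine and a methyl and removes the vinyl group all at once, so which of these changes carries the step stays open. Also open, on these data alone, is how an aryl group bearing a nitrile or a methoxy group would behave on this carbonyl carbon.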